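The source may hold more compounds than are shown below. What is called first, only, known or untested is meant among the compounds shown, and "the series" means these compounds.

Within the data shown here, compound 2 `Cn1c(COc2cccc(C(=O)O)c2)nc2ccc(Oc3ncccc3Cl)cc21` gives 1.1 in a physicochemical assay for lipophilicity, read by LC-MS, in phosphate buffer, measured as octanol-water partition, with a stated time of 30 min, at pH 7.4, tested at 200 mM (on this read-out lower numbers stand for lower lipophilicity and higher numbers for higher lipophilicity), and so stands at the lower of the two numbers so far; compound 1 `Cn1c(COc2cccc(C(=O)O)c2)nc2ccc(Oc3ccc(F)cc3)nc21` gives 1.5 in this assay, a number beyond the scatter higher, though the two structures differ in more than one place and no single step between them is counted. Compound 3 `Cn1c(COc2cccc(C(=O)O)c2)nc2ccc(Oc3ccc(F)cn3)cc21` has not been measured. It differs from compound 2 by 5-fluoropyridin-2-yl in place of 3-chloropyridin-2-yl on an oxygen on an aromatic ring. Among the measured compounds shown here, with no counted step between measured compounds to lean on, the expectation for compound 3 rests on the structural change alone: a chlorine leaves and a fluorine enters, and the step from compound 2 to compound 3 is expected to be a number 0.40 log units lower from compound 2 to compound 3 (beyond the scatter), a modest drop that may only just reach beyond the scatter. On that basis compound 3 is estimated at 0.7 in this assay, with a likely range from 0.3 to 1.1.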

Compound 3, distribution coefficient: 0.6
Compound 3: middle estimate off by 0.10 log units, on the high side, and the stated range covers the measured number.
By their numbers in this assay, from the lowest: compound 3; then compound 2; then compound 1.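

In this assay, among these compounds, the exchange of 3-chloropyridin-2-yl for 5-fluoropyridin-2-yl on an oxygen on an aromatic ring amounts to a number 0.50 log units lower from compound 2 to compound 3 (beyond the scatter) and is the first step here that changes one place only. It shows that the read-out at this position responds to the group's substitution even though the two groups match in every count of atoms, donors, acceptors and charge. Nothing among the available data accounts for the size or the direction of this step.

The step changes the halogen and its ring position together, so the compounds shown cannot separate the contribution of either one. They also leave open how an unsubstituted pyridin-2-yl, or a pyridin-2-yl carrying an amine or a methoxy group, would read in this assay at this place.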